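Chloro for Fluoro on a Long-Chain Compound

The compounds below may be only part of what the source reports. "The series", "measured", "known", "first", "only" and "open" are said of these compounds alone.

In a functional assay on HCT-116 cells (Homo sapiens) for antiproliferative activity, read by MTT assay, with a stated time of 48 h (on this read-out higher numbers stand for weaker inhibition and lower numbers for stronger inhibition), compound 1 (`CCCCCC(CCO)n1cnc2c(Cl)nc(Cl)nc21`) gives 6170 nM and compound 2 (`CCCCCCC(CCO)n1cnc2c(Cl)nc(Cl)nc21`) gives 12100 nM while compound 3 (`CCCCCCCC(CCO)n1cnc2c(Cl)nc(F)nc21`) gives 17600 nM as its reading. Compound 3 thus lies within the scatter of compound 2 and beyond the scatter from compound 1, on the higher, weaker side.

Compound 4 (`CCCCCCCC(CCO)n1cnc2c(Cl)nc(Cl)nc21`) keeps the chain of compound 3 and changes in one place: chloro in place of fluoro on an aromatic carbon. Among the measured compounds shown here, no measured step makes this swap, so its size cannot be read directly. For the measured compounds named here, the only measured step is a chain change (a 2.0-fold higher number from compound 1 to compound 2 (0.29 log units; within the scatter)), and it stays within the scatter. Compound 2 shows the same chloro groups on a shorter chain, and its value of 12100 nM lies close to that of compound 3. In this assay no step beyond the scatter is therefore expected in either direction (a 1.2-fold lower number from compound 3 to compound 4 (0.07 log units; within the scatter)). For compound 4 the estimated value is 15000 nM with an expected range from 6500 nM to 32000 nM as its likely span.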

Compound 4, half-maximal inhibitory concentration: 12800 nM
Compound 4: middle estimate off by 1.2-fold (0.07 log units), on the high side, within the range that was stated.
By their numbers in this assay, from the lowest: compounds 1, 2, 4 and 3 (each within the scatter of the next, the first and the last beyond it).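

In this assay, among the compounds shown here, chloro in place of fluoro on the aromatic carbon between two ring nitrogen atoms gives a 1.4-fold lower number from compound 3 to compound 4 (0.14 log units; within the scatter), so this long-chain pair offers the first direct look at the swap, and the two halogens cannot be told apart here. With both chloro groups kept, methyl in place of hydrogen on the chain gives a 1.1-fold higher number from compound 2 to compound 4 (0.02 log units; within the scatter), whereas ethyl in place of hydrogen gives a 2.1-fold higher number from compound 1 to compound 4 (0.32 log units; beyond the scatter), so among these three dichloro compounds only the larger chain change clears the scatter, and it does so modestly. No supporting measurement is available to explain these results.

From the compounds shown here alone, it remains open whether an amine or a methoxy group on that same aromatic carbon would read differently from chloro and fluoro. Also open, going by these compounds, are whether the swap behaves alike on a shorter chain and whether a still longer chain would further raise the number.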